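The compounds below may be only part of what the source reports. "The series", "measured", "known", "first", "only" and "open" are said of these compounds alone.

Compound 1 `CC(C)(C)C1=NN(c2ccc(F)cc2)C(c2ccc(O)cc2)C1` and compound 2 `CC(C)(C)C1=NN(c2ccc(Br)cc2)C(c2ccc(O)cc2)C1` share one core and differ only by bromo in place of fluoro on an aromatic carbon. In an assay on isolated protein for inhibition of protein kinase C zeta type (Homo sapiens), with a stated time of 4 min (on this read-out lower numbers stand for stronger inhibition and higher numbers for weaker inhibition), compound 1 gives 9400 nM, and compound 2 gives 11400 nM. Compound 2 therefore stands at the higher of the two numbers measured, but the step of a 1.2-fold higher number from compound 1 to compound 2 (0.08 log units; within the scatter) lies within the scatter, so the two compounds are not separated by this measurement. Compound 3 `CC(C)(C)C1=NN(c2ccc(C(F)(F)F)cc2)C(c2ccc(O)cc2)C1` is the next member of the set, and it differs from compound 2 in one place: trifluoromethyl in place of bromo on an aromatic carbon. For the measured compounds named here, the only measured step that bears on this position is the step of a 1.2-fold higher number from compound 1 to compound 2 (0.08 log units; within the scatter), which exchanged one group on that same aromatic carbon without any change beyond the scatter. On that basis compound 3 is expected to stay close to compound 2, the estimated step of a 1.0-fold lower number from compound 2 to compound 3 (0.02 log units; within the scatter) in this assay amounting to nothing beyond the scatter. The estimate for compound 3 in this assay is 11000 nM, with a range from 4000 nM to 30000 nM.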

Compound 3, half-maximal inhibitory concentration: 8800 nM
For compound 3 the middle estimate is 1.3-fold (0.10 log units) above the measured one, and the stated range covers the measured number.
By their numbers in this assay, from the lowest: compounds 3, 1 and 2 (each within the scatter of the next).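

The exchange of bromo for trifluoromethyl gives a 1.3-fold lower number from compound 2 to compound 3 (0.11 log units; within the scatter) in this assay, and the exchange of fluoro for trifluoromethyl gives a 1.1-fold lower number from compound 1 to compound 3 (0.03 log units; within the scatter). The earlier pair compared only two single halogen atoms on this aromatic carbon, whereas compound 3 shows that trifluoromethyl, which has more heavy atoms than either, is also not separated from them in this measurement. Across these three compounds, the choice among fluoro, bromo and trifluoromethyl at this place, para to a large group, produces no step beyond the scatter, and nothing at hand offers an explanation for this.

Going by these compounds, it remains open whether an amine, a carboxylic acid or a longer carbon chain on the same aromatic carbon would also stay within the scatter of these three compounds. Also open is how far the number depends on the hydroxyl group or the tert-butyl group of the shared core, since both stay the same throughout the compounds shown.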